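Vinyl in place of iodo: expected effect on growth inhibition

The source may hold more compounds than are shown below. What is called first, only, known or untested is meant among the compounds shown, and "the series" means these compounds.

In a functional assay on NFS-60 cells (Mus musculus) for inhibition, with a stated time of 72 h (on this read-out higher numbers stand for weaker inhibition of growth and lower numbers for stronger inhibition of growth), compound 1 `Nc1ncnc2c(C(=O)Nc3cccc4c3c(Br)nn4Cc3ccccc3)csc12` gives 1010 nM and compound 2 `Cc1cccc(Cn2nc(I)c3c(NC(=O)c4csc5c(N)ncnc45)cccc32)n1` gives 30 nM as the lower of the two numbers, a gap beyond the scatter. Compound 3 `C=Cc1nn(Cc2cccc(C)n2)c2cccc(NC(=O)c3csc4c(N)ncnc34)c12` has vinyl in place of iodo on an aromatic carbon and is not yet measured. Going by the values given here, no measured step shows the effect of this change, so the expectation rests on compound 2 at 30 nM alone. In this assay a small change toward weaker inhibition of growth, within the scatter, is expected, with a 1.5-fold higher number from compound 2 to compound 3 (0.18 log units; within the scatter) as the estimate. For compound 3 the estimated value is 45 nM with an expected range from 14 nM to 150 nM in this assay.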

Compound 3, concentration for 50% growth inhibition: 4460 nM
The estimate for compound 3 lay 99-fold (2.00 log units) below the measured number, and the stated range ends below it.
By their numbers in this assay, from the lowest: compound 2; then compound 1; then compound 3.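

Notes on the series: in this assay, the aromatic carbon of the five-membered aromatic ring with 2 nitrogen now has its first single-place step, and vinyl in place of iodo gives a 150-fold higher number from compound 2 to compound 3 (2.17 log units; beyond the scatter). This position therefore does not tolerate every small carbon group, and the size of the number here depends strongly on the group carried. Nothing measured on these compounds explains the size of this step. On these data alone, it remains open whether the loss is specific to vinyl or follows any replacement of iodo. An ethyl group or a nitrile on this carbon would help separate these two readings.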